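The source may report more compounds than this note shows. Statements on the series, on what has been measured and on what is new or still open speak of the compounds shown alone.

Two compounds of the series have been run in a functional assay on CFPAC-1 cells (Homo sapiens) for inhibition, read by MTT assay, with a stated time of 72 h; a higher number here means a weaker inhibitor, a lower number a stronger inhibitor. Compound 1 `O=c1cc(Cn2cc(CSC(=S)N3CCNCC3)nn2)c2ccc(O)cc2o1` returns only a limit in this assay, > 100000 nM, so no number is obtained for it. Going by the values given here, compound 2 `Cn1c(-c2cn(Cc3cc(=O)oc4cc(O)ccc34)nn2)nc2ccccc21` gives 76500 nM in this assay, which is the only number measured so far. The other value, that of compound 1, is a limit (the limit of > 100000 nM in this assay, at which 1 of the 2 values shown sits). Compound 3 `Cc1ccc2c(Cn3cc(-c4nc5ccccc5n4C)nn3)cc(=O)oc2c1` is not yet measured. It differs from compound 2 in one place: methyl in place of hydroxy on an aromatic carbon. Among the compounds with values here, no step between measured compounds that differ in one place is available, so the size of this change cannot be read from the series itself. The step of a 1.2-fold higher number from compound 2 to compound 3 (0.07 log units; within the scatter) is expected to lie within the scatter or to weaken inhibition only slightly, given that compound 2 sits at 76500 nM. Compound 3 is estimated at 90000 nM, with a range of 30000 nM to 300000 nM, and a real chance that this assay returns only a limit.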

Compound 3, half-maximal inhibitory concentration: 59400 nM
Compound 3: middle estimate off by 1.5-fold (0.18 log units), on the high side; measured number inside the range.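

In this assay, going by these compounds alone, methyl in place of hydroxy on an aromatic carbon gives a 1.3-fold lower number from compound 2 to compound 3 (0.11 log units; within the scatter), the first step that can be read. The hydrogen-bond donor and acceptor counted on the hydroxy leave with it, yet the two values remain within the scatter of each other. In this one pair, then, the hydroxy and the methyl cannot be told apart at this position on the shared core.

Compound 1 remains a limit rather than a number, so no step involving it can be read: the limit of > 100000 nM in this assay, at which 1 of the 3 values shown sits.
On these data alone, whether an amine or a carboxylic acid at this position would shift the number beyond the scatter remains open, as does whether the same change would read alike on a different core.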